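The source may hold more compounds than are shown below. What is called first, only, known or untested is meant among the compounds shown, and "the series" means these compounds.

Measured in an ADME assay on microsomes from liver (Homo sapiens) for metabolic stability; a higher number here means faster removal of the compound, a lower number slower removal:
- compound 1 `CCCC(Oc1ccc(-n2cc3ccccc3n2)cc1)c1ccc(C(=O)NCCC(=O)O)cc1`: 44 mL/min/kg
- compound 2 `O=C(O)CCNC(=O)c1ccc(C(Oc2ccc(-n3cc(C(F)(F)F)cn3)cc2)C2CCC2)cc1`: 26 mL/min/kg
- compound 3 `CCCC(Oc1ccc(-n2cc3c(n2)CCCC3)cc1)c1ccc(C(=O)NCCC(=O)O)cc1`: 48 mL/min/kg

In this assay, compound 2 at 26 mL/min/kg sits within the scatter of both compound 1 and compound 3, so the set shows no clear separation. The next comparison is compound 4 `CC(C)CC(Oc1ccc(-n2cc(C(F)(F)F)cn2)cc1)c1ccc(C(=O)NCCC(=O)O)cc1`, with isobutyl in place of cyclobutyl on a saturated chain carbon bound to an aromatic carbon and an oxygen on an aromatic ring. In words, isobutyl stands in place of cyclobutyl on a saturated chain carbon bound to an aromatic carbon and an oxygen on an aromatic ring.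

Within the data shown here, no measured step covers this change. The only one available, a 1.1-fold higher number from compound 1 to compound 3 (0.04 log units; within the scatter), lies at another place in the molecule, stays within the scatter and bears on this change only indirectly. Compound 1 and compound 3 have an open chain at the site in question, but they also differ from compound 2 in the group on the other aromatic ring, so they give no clean reading.

No step beyond the scatter is expected, with at most a slight upward lean. The expected step is a 1.2-fold higher number from compound 2 to compound 4 (0.09 log units; within the scatter). For compound 4 the estimated value is 32 mL/min/kg, with an expected range of 18 mL/min/kg to 55 mL/min/kg.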

Compound 4, clearance: 23 mL/min/kg
Beside the measured number, compound 4's estimate is 1.4-fold (0.14 log units) above it; the range from low to high includes it.
By their numbers in this assay, from the lowest: compounds 4, 2, 1 and 3 (each within the scatter of the next, the first and the last beyond it).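

Among these compounds, the first reading at the saturated chain carbon bound to an aromatic carbon and an oxygen on an aromatic ring, with the rest of the molecule unchanged, comes from this assay: isobutyl in place of cyclobutyl gives a 1.1-fold lower number from compound 2 to compound 4 (0.05 log units; within the scatter). Replacing the four-membered ring with an open chain of the same heavy-atom count therefore does not separate the two compounds in this read-out. Nothing available here explains why the two groups read alike.

The compounds shown leave open whether a larger or different group at this place, such as phenyl or an amine, would give a step beyond the scatter. They also leave open whether the isobutyl and cyclobutyl pair would read the same way with the groups carried by compound 1 and compound 3 on the other aromatic ring.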